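From pentyl to 4-butylphenyl on the shared core

This account rests on a few compounds, and the source may have more. Where it says the series, first, only, none or still open, it means among the compounds named here.

Compound 1 `CCCCCc1cc(-c2cn([C@H]3C[C@H](OC(C)=O)[C@@H](COC(C)=O)O3)c(=O)[nH]c2=O)on1` is the lower of the two measured compounds in a functional assay on MDA-MB-231 cells (Homo sapiens) for cytotoxicity, read by sulforhodamine B assay, tested at 10 uM (on this read-out lower numbers stand for less inhibition and higher numbers for more inhibition at the one concentration tested (going by the name of the read-out)), where compound 1 gives 91.5%. Compound 2 `O=c1[nH]c(=O)n([C@H]2C[C@H](O)[C@@H](CO)O2)cc1-c1cn(Cc2ccccc2)nn1` gives 103% in this assay, a gap beyond the usual scatter. Compound 3 `CCCCc1ccc(-c2cc(-c3cn([C@H]4C[C@H](OC(C)=O)[C@@H](COC(C)=O)O4)c(=O)[nH]c3=O)on2)cc1` is not yet measured; it differs from compound 1 by 4-butylphenyl in place of pentyl on an aromatic carbon. Among the measured compounds shown here, no measured pair shows a change of this kind, and compound 1 already has a high number in this assay at 91.5%. The step of a number 1.5 percentage points higher from compound 1 to compound 3 (within the scatter) is therefore expected to stay within the scatter, with no clear direction. Compound 3 is estimated at 93% in this assay, within 75% to 105%.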

Compound 3, a percentage reported as inhibition, at one concentration (the size of the read-out at that concentration, not a potency): 72.2%
Compound 3: middle estimate off by 20.8 percentage points, on the high side; the measured number lies below the stated range.
By their numbers in this assay, from the lowest: compound 3; then compound 1; then compound 2.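

At this aromatic carbon of the five-membered aromatic ring, the group matters: in this assay, 4-butylphenyl in place of pentyl gives a number 19.3 percentage points lower from compound 1 to compound 3 (beyond the scatter). Among the compounds shown here, this single pair is the first sign that the position responds to a change of group, and it covers only this one swap on the shared core. Nothing available explains the fall.

The aromatic ring and the larger count of heavy atoms enter together here, so the pair cannot separate them. On these data alone, how a plain phenyl, an amine or a carboxylic acid at this carbon would read in this assay stays open.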